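The compounds below may be only part of what the source reports. "The series", "measured", "known", "first", "only" and "open" are said of these compounds alone.

Working notes on the series. In a physicochemical assay for solubility, read by HPLC, using the shake flask method, in phosphate buffer, with a stated time of 20 h, at pH 6.5 (a higher number here means a more soluble compound, a lower number a less soluble compound), compound 1 `NC1CCN(c2nccc3[nH]c(-c4ccc(F)c(F)c4)nc23)CC1` gives 200000 nM. Compound 2 `CN1CCN(C2CCN(c3nccc4[nH]c(-c5ccc(F)c(F)c5)nc34)CC2)CC1` gives 130000 nM, which lies within the scatter of compound 1, so the two cannot be separated on these numbers. Compound 3 `CN1CCN(CC2CCN(c3nccc4[nH]c(-c5ccc(F)c(F)c5)nc34)CC2)CC1` has (4-methylpiperazin-1-yl)methyl in place of 4-methylpiperazin-1-yl on a saturated ring carbon. Among the compounds with values here, only one measured step bears on this change: a 1.5-fold lower number from compound 1 to compound 2 (0.19 log units; within the scatter), which replaces amino with 4-methylpiperazin-1-yl on a saturated ring carbon and stays within the scatter. Within the data shown here, with that step as the only guide, no step beyond the scatter is expected in this assay, and no direction can be called with confidence. The estimated step is a 1.1-fold lower number from compound 2 to compound 3 (0.03 log units; within the scatter), which is expected to stay within the scatter. Compound 3 is estimated at 120000 nM, with an expected range of 55000 nM to 250000 nM.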

Compound 3, solubility: 195000 nM
Compound 3: the middle estimate sits 1.6-fold (0.21 log units) below what was measured, within the range that was stated.
By their numbers in this assay, from the lowest: compounds 2, 3 and 1 (each within the scatter of the next).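

The extended group changes little in this assay: (4-methylpiperazin-1-yl)methyl in place of 4-methylpiperazin-1-yl on the saturated ring carbon gives a 1.5-fold higher number from compound 2 to compound 3 (0.18 log units; within the scatter), so the earlier flat reading for this position now holds for a second change. Within the data shown here, measured against the small amino group, the same extended group gives a 1.0-fold lower number from compound 1 to compound 3 (0.01 log units; within the scatter), which places compounds 1, 2 and 3 all within the scatter of one another, with no compound among them going against this flat picture. No supporting measurement is available to explain these results.

As far as these compounds go, whether a carboxylic acid, a morpholine or a longer chain carrying the 4-methylpiperazin-1-yl group on this saturated ring carbon would give a step beyond the scatter remains open. From the compounds shown here alone, whether the same flat picture would hold on a core other than the shared core also remains open.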